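Anilide substituent change and cytotoxicity within the series

The source may hold more compounds than are shown below. What is called first, only, known or untested is meant among the compounds shown, and "the series" means these compounds.

Measured compounds:
Compound 1, `COc1ccc(-c2nnsc2SCC(=O)Nc2ccccc2Cl)cc1`, in an ADME assay on MT4 cells (Homo sapiens) for cytotoxicity (on this read-out higher numbers stand for lower toxicity in this test and lower numbers for higher toxicity in this test), gives > 318000 nM.
Compound 2, `COc1ccc(-c2nnsc2SCC(=O)Nc2ccccc2[N+](=O)[O-])cc1`, in this assay gives >= 280000 nM.

Both values are limits of this assay, not numbers. Compound 1 sits at the limit of > 318000 nM in this assay, at which 1 of the 2 values shown sits. Compound 2 sits at the limit of >= 280000 nM in this assay, at which 1 of the 2 values shown sits. For the measured compounds named here, the step that the two limits leave unreadable from compound 1 to compound 2 is therefore unreadable; compound 2 stands at a limit, as does the only other compound measured.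

Compound 3, `COc1ccc(-c2nnsc2SCC(=O)Nc2ccccc2F)cc1`, differs from compound 2 by fluoro in place of nitro on an aromatic carbon. Going by the values given here, no measured step resolves a size for such a change, since the one step available is hidden by two limits. The expectation for compound 3 rests on compound 2 standing at >= 280000 nM and on compound 1 standing at a limit as well. The step that the limit leaves unreadable from compound 2 to compound 3 is expected to be none beyond the scatter. Compound 3 is estimated at 300000 nM, with a range from 100000 nM to 900000 nM, most likely reported again only as a limit.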

Compound 3, half-maximal cytotoxic concentration: > 332000 nM
Compound 3 was reported as a limit; the forecaster's own chance of this, stated with the estimate: 70%; at least 1.1-fold (0.04 log units) between middle value and limit.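

For the compounds shown here, the values of compound 1, compound 2 and compound 3 are all limits, and no step among them can be read. The compounds shown leave open whether chloro, nitro and fluoro differ at all in cytotoxicity, and at what concentration any of the three becomes toxic.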